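The source may hold more compounds than are shown below. What is called first, only, known or untested is meant among the compounds shown, and "the series" means these compounds.

Values measured in a functional assay on THP-1 cells (Homo sapiens) for inhibition, read by sulforhodamine B assay, with a stated time of 48 h, tested at 50 uM; on this read-out higher numbers stand for more inhibition of growth at the one concentration tested and lower numbers for less inhibition of growth
compound 1 `O=C1C(=O)N(CCCCn2cc(COc3cc(=O)oc4ccccc34)nn2)c2ccc([N+](=O)[O-])cc21` gives 55%
compound 2 `O=C1C(=O)N(CCCCn2cc(COc3cc(=O)oc4ccccc34)nn2)c2ccc(Br)cc21` gives 63%
compound 3 `O=C1C(=O)N(CCCCn2cc(COc3cc(=O)oc4ccccc34)nn2)c2ccc(Cl)cc21` gives 71%

Compound 3 stands at the top of this short series only in part. It cannot be separated from compound 2 (see a number 8 percentage points higher from compound 2 to compound 3 (within the scatter)), but it does stand clear of compound 1 (see a number 16 percentage points higher from compound 1 to compound 3 (beyond the scatter)). The next analogue, compound 4 `O=C1C(=O)N(CCCCn2cc(COc3cc(=O)oc4ccccc34)nn2)c2ccc(F)cc21`, differs from compound 3 by a single exchange, fluoro in place of chloro on an aromatic carbon (in full, (fluoro in place of chloro on an aromatic carbon)).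

Among the measured compounds shown here, the closest precedent is the one exchange of halogen for halogen, chloro in place of bromo, and it stayed small (see a number 8 percentage points higher from compound 2 to compound 3 (within the scatter)). The exchanges of nitro are less direct guides, and they ranged from a number 8 percentage points higher from compound 1 to compound 2 (within the scatter) to a number 16 percentage points higher from compound 1 to compound 3 (beyond the scatter). For the measured compounds named here, no fluoro compound has yet been measured, so these steps suggest no clear direction, and no change beyond the scatter is expected in this assay. The estimated change is small (expected: a number 4 percentage points lower from compound 3 to compound 4 (within the scatter)). Compound 4 is expected to give 67% (estimated range 55% to 79%).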

Compound 4, percent growth inhibition at one concentration: 77%
Estimate against measurement, compound 4: 10 percentage points below, and the stated range covers the measured number.
By their numbers in this assay, from the lowest: compounds 1, 2, 3 and 4 (each within the scatter of the next, the first and the last beyond it).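

Replacing chloro with fluoro on this aromatic carbon leaves this assay unable to separate the two halogens (a number 6 percentage points higher from compound 3 to compound 4 (within the scatter)). Fluoro does, however, give the first exchange of one halogen for another that passes the scatter (a number 14 percentage points higher from compound 2 to compound 4 (beyond the scatter)), whereas chloro in place of bromo did not, and it also stands clear of nitro (a number 22 percentage points higher from compound 1 to compound 4 (beyond the scatter)), so compound 4 and compound 3 now share the top of the series, and only compound 4 stands clear of compound 2. Nothing given here explains why these halogens differ in this way.

Still open, as far as these compounds go, is how an amine, a methoxy group or a plain hydrogen on the same carbon would compare with fluoro and chloro. Equally open, from the compounds shown here alone, is whether a longer chain in place of the present one would keep this level of growth inhibition.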